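Replacing 4-phenylphenyl at a cytotoxicity limit

A few compounds are considered here, and "the series" means these few. Any claim that something is new, unique, unknown or untested is made for them only; others in the source may bear on it.

Of the compounds shown here, three have been tested in an ADME assay on CHO cells (Cricetulus griseus) for cytotoxicity, read by MTT assay, with a stated time of 24 h (on this read-out higher numbers stand for weaker inhibition and lower numbers for stronger inhibition), so far. Compound 1 `O=C(Nc1ccc(Oc2ccccc2)cc1)C1=CO[C@@H](O[C@@H]2O[C@H](COCc3ccccc3)[C@@H](OCc3ccccc3)[C@H](OCc3ccccc3)[C@H]2OCc2ccccc2)[C@@H]2C(COCc3ccccc3)=CC[C@H]12` gives > 200000 nM as a limit and not a number. Compound 2 `CCOS(=O)(=O)/C=C/c1ccc(OCC2=CC[C@@H]3C(C(=O)Nc4ccc(Oc5ccccc5)cc4)=CO[C@@H](OC)[C@H]23)cc1` gives > 200000 nM as a limit too. Compound 3 `CCOS(=O)(=O)/C=C/c1ccc(OCC2=CC[C@@H]3C(C(=O)Nc4ccc(Oc5ccc(-c6ccccc6)cc5)cc4)=CO[C@@H](OC)[C@H]23)cc1` gives > 200000 nM as a limit as well, so it has no exact value to start from.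

The change to compound 4 `CCOS(=O)(=O)/C=C/c1ccc(OCC2=CC[C@@H]3C(C(=O)Nc4ccc(Oc5ccc(Br)cc5Cl)cc4)=CO[C@@H](OC)[C@H]23)cc1` is 4-bromo-2-chlorophenyl in place of 4-phenylphenyl on an oxygen on an aromatic ring and puts 4-bromo-2-chlorophenyl in place of 4-phenylphenyl on an oxygen on an aromatic ring. Going by the values given here, the one measured step is a step that the two limits leave unreadable from compound 2 to compound 3 for phenyl in place of hydrogen on an aromatic carbon, and it offers no size to carry over.

No step beyond the scatter is expected in this assay because of the limit of > 200000 nM in this assay, at which 3 of the 3 values shown sit, and no direction can be drawn from these results. The expected size is a number no higher from compound 3 to compound 4 (the limit leaves the size open) on this estimate. Compound 4 is estimated at 200000 nM with an expected range from 90000 nM to 400000 nM and a limit rather than an exact number is expected for it.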

Compound 4, half-maximal inhibitory concentration: > 200000 nM
Compound 4: no number, only a limit; the forecaster's own chance of this, stated with the estimate: 85%; the middle value lies on the limit itself.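

No step can be read from compound 2 or compound 3 to compound 4, because these results are limits and not numbers: the limit of > 200000 nM in this assay, at which 4 of the 4 values shown sit.

The compounds shown leave open how any of these structural changes affects the actual value in this assay.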